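Terminal hydroxyl in place of the decyl chain end

The source may hold more compounds than are shown below. What is called first, only, known or untested is meant among the compounds shown, and "the series" means these compounds.

Compound 1, `CCCCCCCCCCOC(C)(C)[C@H](O)COc1ccc(C(CC)(CC)c2ccc(OC[C@@H](O)CO)c(C)c2)cc1C`, is reported without a number in an assay on HEK293 cells for agonist activity at vitamin D3 receptor (Homo sapiens), read by a beta-galactosidase reporter; a higher number here means that more compound is needed for the effect, a lower number that less compound is needed: it is simply described as "not active" (no number reported). Compound 2, `CCCCCCCCCCOC(C)(C)[C@@H](O)COc1ccc(C(CC)(CC)c2ccc(OC[C@@H](O)CO)c(C)c2)cc1C`, is likewise reported as "not active" (no number reported) in this assay, and (the fact that compounds 1 and 2 differ only in the configuration as drawn). Among the compounds with values here, the only compound of the set with a number is compound 3, `CCCCCCOC(C)(C)[C@@H](O)COc1ccc(C(CC)(CC)c2ccc(OC[C@@H](O)CO)c(C)c2)cc1C`, which in this assay gives 1500 nM; compound 3 carries a hexyl ether in place of the decyl ether of compound 1, and no measured step between the two is given, so one can say only that compound 3 has a number and compound 1 does not.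

Compound 4, `CCC(CC)(c1ccc(OC[C@@H](O)CO)c(C)c1)c1ccc(OC[C@@H](O)C(C)(C)OCCCCCCCCO)c(C)c1`, differs from compound 1 in one place: hydroxy in place of ethyl on a saturated chain carbon, eight bonds along the chain from an oxygen on a saturated carbon. Within the data shown here, because compound 1 is reported as "not active" (no number reported), no step can be stated for it; the writer expects compound 4 to move from inactive toward a measurable value in this assay, since the only measured member of this series, compound 3, gives 1500 nM with a hexyl ether tail, though the size of that step is unknown. Compound 4 is accordingly estimated at 1500 nM in this assay, within a range of 200 nM to 15000 nM, with a real chance that it too is reported only as inactive.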

Compound 4, half-maximal effective concentration: > 3000 nM
Compound 4: no number, only a limit; the forecaster's own chance of this, stated with the estimate: 40%; middle value at least 2.0-fold (0.30 log units) from the limit.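

In this assay compound 4 gives > 3000 nM, which is a limit and not a number. Compound 1 has no number either, so no step can be read from compound 1 to compound 4. The compounds shown leave open how far hydroxy in place of ethyl shifts the value in this assay, if it shifts it at all.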